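Second fluoro on the fused ring of compound 2

A few compounds are considered here, and "the series" means these few. Any claim that something is new, unique, unknown or untested is made for them only; others in the source may bear on it.

Measured so far in a functional assay on the whole organism with Mus musculus as the target, at a dose of 100 mg/kg by the intraperitoneal route; on this read-out higher numbers stand for more inhibition at the one dose given (going by the name of the read-out) and lower numbers for less inhibition:
- compound 1, `Cc1cccc2c1CC/C2=C\C(=O)NC1CC1`, gives 100%
- compound 2, `NC(=O)/C=C1\CCc2c(F)cccc21`, gives 63%
- compound 3, `NC(=O)/C=C1\CCc2cc(Cl)ccc21`, gives 0%

Among these three numbers compound 2 stands second highest. Compound 1 sits above it by a margin beyond the scatter, and compound 3 sits below it by a margin that is also beyond the scatter. Among the compounds with values here, no two of the measured compounds differ in only one place, so no single step between them can be read off.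

Compound 4, `NC(=O)/C=C1\CCc2c(F)cc(F)cc21`, has not been tested. It differs from compound 2 by fluoro in place of hydrogen on an aromatic carbon. The new fluoro sits on the six-membered aromatic ring of the fused system, on a carbon meta to the fluoro already present.

Within the data shown here, with no comparable step among the measured compounds, the size and direction of this change can only be guessed. The account expects the step from compound 2 to compound 4 in this assay to be small, a number 13 percentage points lower from compound 2 to compound 4 (beyond the scatter), not clearly beyond the scatter in either direction. Compound 4 is therefore estimated at 50% in this assay, with a range from 15% to 85%.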

Compound 4, a percentage reported as inhibition, in the whole organism at one dose (the size of the read-out at that dose, not a potency): 67%
The estimate for compound 4 lay 17 percentage points below the measured number; low and high end bracket the measured number.
By their numbers in this assay, from the lowest: compound 3; then compounds 2 and 4 (each within the scatter of the next); then compound 1.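

In this assay, within the data shown here, fluoro in place of hydrogen on this aromatic carbon, meta to the fluoro group already present, gives a number 4 percentage points higher from compound 2 to compound 4 (within the scatter), the first step that can be read from one change alone. The six-membered aromatic ring of compound 2 thus accepts a second fluoro at this carbon with no difference beyond the scatter, so this single replacement leaves the read-out where it was. Nothing at hand accounts for this result.

On these data alone, it remains open whether an amine, a methoxy group or a trifluoromethyl group on the same carbon would also leave the number in place. As far as these compounds go, it is also open whether this fluoro step would hold on a compound carrying the cyclopropyl group on the amide, as compound 1 does.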